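Oxime in place of hydroxypropyl on the benzoxazole-free core

This account rests on a few compounds, and the source may have more. Where it says the series, first, only, none or still open, it means among the compounds named here.

Compound 2 `CCC(O)c1ccc2oc(CSc3nnc(CNc4ccccc4)n3CC)nc2c1` gives 3700 nM in an assay on isolated protein for inhibition of long-chain fatty acid transport protein 1 (Mus musculus) (on this read-out lower numbers stand for stronger inhibition and higher numbers for weaker inhibition), the highest of the two numbers recorded so far. Its nearest neighbour is compound 1 `CCc1ccc2oc(CSc3nnc(CNc4ccccc4)n3CC)nc2c1`, which in this assay gives 1800 nM. Going by the values given here, the single step between measured compounds runs a 2.1-fold higher number from compound 1 to compound 2 (0.31 log units; beyond the scatter), a 1-hydroxypropyl in place of ethyl on an aromatic carbon.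

Compound 3 `CC/C(=N/O)c1ccc2oc(CSc3nnc(CNc4ccccc4)n3CC)nc2c1` carries a group of 5 heavy atoms (3 carbon, 1 nitrogen, 1 oxygen; no ring) in place of a group of 4 heavy atoms (3 carbon, 1 oxygen; no ring), on an aromatic carbon. The new group has no common name; it brings one double bond outside aromatic rings, one hydrogen-bond donor and two hydrogen-bond acceptors where the 1-hydroxypropyl of compound 2 had one donor and one acceptor, at the same place on the shared core.

Among the compounds with values here, no measured step covers this change: the only step at hand swaps ethyl for 1-hydroxypropyl and was modest. On that basis the expected step in this assay is a 1.1-fold lower number from compound 2 to compound 3 (0.02 log units; within the scatter), i.e. no movement beyond the scatter in either direction, with a wide range because the data give no guide. Compound 3 is therefore estimated at 3500 nM in this assay, between 1200 nM and 10000 nM.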

Compound 3, half-maximal inhibitory concentration: 200 nM
The estimate for compound 3 lay 18-fold (1.24 log units) above the measured number, outside the stated range (below it).
By their numbers in this assay, from the lowest: compound 3; then compound 1; then compound 2.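

This position, an aromatic carbon of the shared core, proves far more responsive in this assay than the earlier swap of ethyl for 1-hydroxypropyl suggested: the oxime-bearing group gives a 19-fold lower number from compound 2 to compound 3 (1.27 log units; beyond the scatter) and so turns a modest loss into a large gain. The same group also outperforms the plain ethyl, with a 9.0-fold lower number from compound 1 to compound 3 (0.95 log units; beyond the scatter) as the step, so its effect is more than a recovery of what the 1-hydroxypropyl gave up, and among these three compounds the lowest number belongs to compound 3, with both of its steps beyond the scatter. No available evidence bears on what lies behind this change.

The compounds shown do not separate the contribution of the oxime hydroxyl from that of the double bond, so the corresponding ketone and the oxime methyl ether remain the direct tests of which part matters. Also open, from the compounds shown here alone, are the oxime of the opposite geometry, a chain longer than the propyl skeleton at this position, and whether the gain carries over when the ethyl on the shared core or the aniline phenyl is replaced.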